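The compounds below may be only part of what the source reports. "The series", "measured", "known", "first", "only" and "open" are said of these compounds alone.

In an ADME assay on Vero cells (Chlorocebus sabaeus) for cytotoxicity, read by MTT assay (a lower number here means a stronger inhibitor, a higher number a weaker inhibitor), compound 1 `C=CCOc1cc(OC)c(C(=O)/C=C/C=C/c2ccccc2)c(OCC=C)c1` gives "not determined" (no result reported) and so offers no number to compare with. For the measured compounds named here, compound 2 `C=CCOc1cc(OC)c(C(=O)/C=C/c2ccccn2)c(OCC=C)c1` gives 2800 nM in this assay and is the only compound with a number, which leaves it without a rank of any kind. Compound 3 `C=CCOc1cc(OC)c(C(=O)/C=C/c2ccc(C)cc2)c(OCC=C)c1` differs from compound 2 in one place, on a double-bonded chain carbon bound to a double-bonded chain carbon, and the change reads 4-methylphenyl in place of pyridin-2-yl on a double-bonded chain carbon bound to a double-bonded chain carbon in the structure. Going by the values given here, no measured pair shows what such a swap does, so the expectation here is a loose one. A moderate weakening is expected, and the estimated change is a 1.8-fold higher number from compound 2 to compound 3 (0.25 log units; within the scatter) in this assay with a real chance of no change beyond the scatter. Compound 3 is therefore estimated at 5000 nM with an expected range from 1500 nM to 20000 nM in this measurement.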

Compound 3, half-maximal inhibitory concentration: 211000 nM
Estimate against measurement, compound 3: 42-fold (1.63 log units) below; the measured number lies above the stated range.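

The swap of pyridin-2-yl for 4-methylphenyl gives a 75-fold higher number from compound 2 to compound 3 (1.88 log units; beyond the scatter) in this assay, so this place on the chain is not indifferent to what it carries. A higher number means a weaker effect on the cells, which makes compound 3 much the weaker of the pair. The swap changes two things at once, removing the ring nitrogen and adding a methyl group, and nothing available here accounts for the size of the step.

On these data alone, how much of the step belongs to the ring nitrogen and how much to the methyl group stays open, and a plain phenyl or a pyridin-4-yl at this place would help to separate the two. Compound 1 gives "not determined" (no result reported), so it adds nothing on the effect of a longer chain.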